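The compounds below may be only part of what the source reports. "The series", "measured", "known", "first", "only" and "open" are said of these compounds alone.

Of the compounds shown here, three have been tested in a functional assay on CCRF-CEM cells (Homo sapiens), read by MTT assay, with a stated time of 72 h (a higher number here means a weaker inhibitor, a lower number a stronger inhibitor), and none of them gave an exact number. Compound 1 `COc1ncnc2c1c(-c1ccccc1)cn2[C@@H]1O[C@H](CO)[C@@H](O)[C@H]1O` gives > 20000 nM, which is a limit of the assay. Compound 2 `Cc1nc(N)c2c(-c3ccoc3)cn([C@@H]3O[C@H](CO)[C@@H](O)[C@H]3O)c2n1`, which carries furan-3-yl, gives > 100000 nM, again a limit. Compound 3 `Nc1nc2c(c(-c3ccco3)cn2[C@@H]2O[C@H](CO)[C@@H](O)[C@H]2O)c(=O)[nH]1`, which carries furan-2-yl, gives > 20000 nM, also a limit. Compound 3 therefore has no exact value, and no order can be read among the three.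

Compound 4 `Nc1nc2c(c(-c3ccoc3)cn2[C@@H]2O[C@H](CO)[C@@H](O)[C@H]2O)c(=O)[nH]1` keeps the core of compound 3 and has furan-3-yl in place of furan-2-yl on an aromatic carbon. The two compounds have the same atoms, joined differently. Among the measured compounds shown here, no two tested compounds differ in one place only, so no measured step can guide this change. The expected shift in this assay is therefore none beyond the usual scatter, and another limit is the likely result. The estimated value for compound 4 is 30000 nM, with an expected range from 10000 nM to 100000 nM.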

Compound 4, half-maximal inhibitory concentration: 17900 nM
Compound 4: the middle estimate sits 1.7-fold (0.22 log units) above what was measured; measured number inside the range.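

In this assay, putting furan-3-yl in place of furan-2-yl on this aromatic carbon gives an at least 1.1-fold lower number from compound 3 to compound 4 (0.04 log units; that floor lies within the scatter). Compound 4 is the first of the compounds shown to return an exact number, which gives this position a measured reference point, though the true size of the step stays unknown. Compound 3 stands at a limit and not at a number: the limit of > 20000 nM in this assay, at which 2 of the 4 values shown sit.

The compounds shown leave open how large this step really is, and whether any group on this aromatic carbon can bring the number much lower. How a thiophene ring, an amine or a longer chain in this place, on the same core, would read in this assay cannot be told from these compounds.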